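This account rests on a few compounds, and the source may have more. Where it says the series, first, only, none or still open, it means among the compounds named here.

Measured so far:
- compound 1, `C=CC(=O)Nc1cc(N)nc(Sc2c(OCC)nc(N3CCN(C)CC3)nc2OCC)n1`: in a functional assay on SK-BR-3 cells (Homo sapiens) for cytotoxicity, read by resazurin assay, with a stated time of 72 h (on this read-out lower numbers stand for stronger inhibition of growth and higher numbers for weaker inhibition of growth), compound 1 gives 1.1 uM
- compound 2, `C=CC(=O)Nc1ccnc(Sc2c(C)nc(N3CCN(C)CC3)nc2C)n1`: in this assay compound 2 gives 1.8 uM

On paper compound 1 shows the lower of the two numbers, but the gap to compound 2 lies within the scatter of repeated measurements of this kind, so the two compounds cannot be told apart and neither can be called the more potent one.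

Compound 3, `CCOc1nc(N2CCN(C)CC2)nc(OCC)c1Sc1nc(N)cc(NC(=O)CC)n1`, has not yet been measured. It differs from compound 1 in one place: ethyl in place of vinyl on a carbonyl carbon. Within the data shown here, compound 2 differs from compound 1 in several places at once, so no measured pair shows what this single change does, and the expectation has to rest on the change itself rather than on a measured step. A move towards a higher number in this assay is expected, meaning weaker inhibition of growth, though with wide uncertainty in both directions. The step from compound 1 to compound 3 is estimated at a 7.3-fold higher number from compound 1 to compound 3 (0.86 log units; beyond the scatter). Compound 3 is expected to give about 8 uM, within a range from 2 uM to 40 uM.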

Compound 3, concentration for growth inhibition (reported as GI): 55 uM
Estimate against measurement, compound 3: 6.9-fold (0.84 log units) below; measured number outside the range, above it.
By their numbers in this assay, from the lowest: compounds 1 and 2 (each within the scatter of the next); then compound 3.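

In this assay, putting ethyl in place of vinyl on a carbonyl carbon whose other neighbour is an amide-type nitrogen gives a 50-fold higher number from compound 1 to compound 3 (1.70 log units; beyond the scatter), a large step that shows growth inhibition in this series is highly sensitive to this one group. The two groups match in every count available here: each has two carbon heavy atoms, no ring, no hydrogen-bond donor or acceptor and no net charge, and the one counted difference is the double bond outside aromatic rings, which vinyl has and ethyl lacks. The data at hand offer no measurement that explains the size of this step.

As far as these compounds go, a single pair cannot separate the presence of the double bond from the exact shape of the vinyl group, so it remains open how a propynoyl group, which carries a triple bond instead, or a longer chain that keeps a double bond would behave at this carbonyl carbon. From the compounds shown here alone, it also remains open whether ethyl in place of vinyl would produce a step of similar size on the core of compound 2.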